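The source may report more compounds than this note shows. Statements on the series, on what has been measured and on what is new or still open speak of the compounds shown alone.

Compound 1 `COc1ccc(-c2coc3cc(OCCCSC(=S)N4CCOCC4)ccc3c2=O)cc1` is the starting point of this step. In a functional assay on MGC-803 cells (Homo sapiens) for inhibition, read by MTT assay, with a stated time of 48 h (a lower number here means a stronger inhibitor, a higher number a weaker inhibitor), compound 1 gives 49600 nM, the highest of the three numbers, although the steps to both neighbours are within the scatter. Compound 2 `COc1ccc(-c2coc3cc(OCCCSC(=S)N4CCN(c5ccccn5)CC4)ccc3c2=O)cc1` gives 42000 nM, and compound 3 `COc1ccc(-c2coc3cc(OCCCSC(=S)N4CCN(C(C)=O)CC4)ccc3c2=O)cc1` gives 39400 nM. The step of a 1.2-fold lower number from compound 1 to compound 2 (0.07 log units; within the scatter) and the step of a 1.3-fold lower number from compound 1 to compound 3 (0.10 log units; within the scatter) both change only the amine on the thiocarbonyl carbon, and the step of a 1.1-fold lower number from compound 2 to compound 3 (0.03 log units; within the scatter) is likewise within the scatter; together they show that this end of the chain can be varied without any change beyond the scatter.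

Compound 4 `COc1ccc(-c2coc3cc(OCCCCBr)ccc3c2=O)cc1` differs from compound 1 in a different way: a group of 2 heavy atoms (1 carbon, 1 bromine; no ring) in place of a group of 9 heavy atoms (5 carbon, 1 nitrogen, 1 oxygen, 2 sulfur; one six-membered non-aromatic ring with 2 hetero atoms), on a saturated chain carbon, three bonds along the chain from an oxygen on an aromatic ring. Among the compounds with values here, none of the measured steps removes the thiocarbonyl group itself, so none bears directly on this change; they only show that the three measured numbers sit close together. The step is therefore expected to be a 1.1-fold higher number from compound 1 to compound 4 (0.04 log units; within the scatter), with wide uncertainty. Compound 4 is estimated at 55000 nM, with a range from 15000 nM to 200000 nM.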

Compound 4, half-maximal inhibitory concentration: 52700 nM
For compound 4 the middle estimate is 1.0-fold (0.02 log units) above the measured one; measured number inside the range.
By their numbers in this assay, from the lowest: compounds 3, 2, 1 and 4 (each within the scatter of the next).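

In this assay, the step of a 1.1-fold higher number from compound 1 to compound 4 (0.03 log units; within the scatter) shows that the entire group carrying the thiocarbonyl, morpholine ring included, can give way to bromomethyl at this saturated chain carbon without a change beyond the scatter. The earlier compounds shown here all kept the thiocarbonyl group and varied only the amine on it, so they could not show that the group as a whole can be exchanged in this way. No measurement offered here gives a reason for this result.

The compounds shown leave open whether a primary amine or a carboxylic acid at this chain carbon, or a longer chain, would move the number beyond the scatter. They also leave open whether any change to the shared core would do so.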